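The source may hold more compounds than are shown below. What is called first, only, known or untested is meant among the compounds shown, and "the series" means these compounds.

Compound 1 `Cc1ncccc1-c1cnc(NCc2c(F)ccc3c2CCO3)c2ncc(=O)[nH]c12` and compound 2 `O=C1CCCN1c1cnc(NCc2c(F)ccc3c2CCO3)c2cn[nH]c(=O)c12` share a core and differ on a six-membered aromatic ring bearing one nitrogen that is part of a fused system. In a physicochemical assay for lipophilicity, using the shake flask method, in phosphate buffer, measured as octanol-water partition, with a stated time of 30 min, at pH 7.4 (on this read-out lower numbers stand for lower lipophilicity and higher numbers for higher lipophilicity), compound 1 gives 2.8. In this assay compound 2 gives 1.8, the lowest of the two numbers shown, below compound 1 and beyond the scatter. Compound 3 `CN(c1ccn(C)n1)c1cnc(NCc2c(F)ccc3c2CCO3)c2cn[nH]c(=O)c12` has not yet been measured in this assay. It differs from compound 2 by one change (methyl(1-methyl-1H-pyrazol-3-yl)amino in place of 2-oxopyrrolidin-1-yl on an aromatic carbon). For the measured compounds named here, no measured pair shows this change, so its size has to be estimated. A moderate rise in this assay is expected for compound 3, with a step of a number 0.70 log units higher from compound 2 to compound 3 (beyond the scatter), placing it between the two measured compounds. The estimate for compound 3 in this assay is 2.5, with a likely range from 2 to 3.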

Compound 3, distribution coefficient: 2.4
Compound 3: the middle estimate sits 0.10 log units above what was measured; low and high end bracket the measured number.
By their numbers in this assay, from the lowest: compound 2; then compound 3; then compound 1.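

In this assay, for the compounds shown here, methyl(1-methyl-1H-pyrazol-3-yl)amino in place of 2-oxopyrrolidin-1-yl on this aromatic carbon gives a number 0.60 log units higher from compound 2 to compound 3 (beyond the scatter), the first measured step at this position. The exchange swaps one five-membered non-aromatic ring with 1 hetero atom and a double bond outside aromatic rings for one five-membered aromatic ring with 2 hetero atoms, so the read-out responds to what stands on this carbon, though this single pair cannot divide the step among those differences. Nothing measured here explains the size of the step.

The compounds shown leave open how a smaller group on this carbon, such as dimethylamino or a plain methoxy, would compare with these two, and where a morpholine ring would fall. They also leave open whether the same exchange would give a step of similar size on the core of compound 1.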